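The source may report more compounds than this note shows. Statements on the series, on what has been measured and on what is new or still open speak of the compounds shown alone.

Compound 1 `CCCCCCCCc1ccc(OCC(=O)Cn2cnc3cccnc32)cc1` gives 410 nM in an assay on microsomes from brain for inhibition of Fatty-acid amide hydrolase 1 (Rattus norvegicus), read by fluorescence and HPLC, with a stated time of 60 min; on this read-out lower numbers stand for stronger inhibition and higher numbers for weaker inhibition. Compound 2 `CCCCCCCCc1ccc(OCC(=O)Cn2nnc3ncccc32)cc1` gives 49 nM. Compound 2 thus holds the lowest of the two measured numbers, set apart by the step of an 8.4-fold lower number from compound 1 to compound 2 (0.92 log units; beyond the scatter).

Compound 3 `CCCCCCCCc1ccc(OCC(=O)Cn2nccn2)cc1` differs from compound 2 in one place: a group of 5 heavy atoms (2 carbon, 3 nitrogen; one five-membered aromatic ring with 3 hetero atoms) in place of a group of 9 heavy atoms (5 carbon, 4 nitrogen; one five-membered aromatic ring with 3 hetero atoms, one six-membered aromatic ring with 1 hetero atom), on a saturated chain carbon bound to a carbonyl carbon. Among the compounds with values here, no measured step bears directly on this change; the only step known, an 8.4-fold lower number from compound 1 to compound 2 (0.92 log units; beyond the scatter), exchanged one fused two-ring group for another rather than trimming a ring away. Within the data shown here, with no closer precedent, a modest rise in this assay is expected. Compound 3 is estimated at 200 nM, within 50 nM to 800 nM. The expected step is a 4.1-fold higher number from compound 2 to compound 3 (0.61 log units; beyond the scatter).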

Compound 3, half-maximal inhibitory concentration: 100 nM
The estimate for compound 3 lay 2.0-fold (0.30 log units) above the measured number, and the stated range covers the measured number.
By their numbers in this assay, from the lowest: compound 2; then compound 3; then compound 1.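

Cutting the two-ring group down to 2H-1,2,3-triazol-2-yl, on a saturated chain carbon bound to a carbonyl carbon, costs only a modest amount in this assay: the step is a 2.0-fold higher number from compound 2 to compound 3 (0.31 log units; beyond the scatter). This small group still does better than the other two-ring group, with a 4.1-fold lower number from compound 1 to compound 3 (0.61 log units; beyond the scatter), so among these three compounds the number does not simply follow group size. Nothing measured here explains this order. As far as these compounds go, whether a lone imidazole or tetrazole would do as well at this place stays open, as does the effect of an amine there.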